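A Weak Pair and One Group Exchanged

This account rests on a few compounds, and the source may have more. Where it says the series, first, only, none or still open, it means among the compounds named here.

In a functional assay on A549 cells (Homo sapiens) for inhibition, read by sulforhodamine B assay, with a stated time of 48 h (on this read-out lower numbers stand for stronger inhibition and higher numbers for weaker inhibition), compound 1 `CCOC(=O)CCO/N=C(/c1ccc(OC)c(OC)c1OC)c1cccc2ccccc12` gives 19600 nM. Compound 2 `COc1ccc(C(c2ccccc2O)c2cccc3ccccc23)c(OC)c1OC` gives 13600 nM, which lies within the usual scatter of compound 1. Compound 3 `COc1ccc(C(OCc2ccc(C)cc2)c2cccc3ccccc23)c(OC)c1OC` has not yet been measured. It has (4-methylbenzyl)oxy in place of 2-hydroxyphenyl on a saturated chain carbon bound to two aromatic carbons. Within the data shown here, no measured step shows what such an exchange does, so no change beyond the scatter is expected, in either direction. The estimated step is a 1.1-fold lower number from compound 2 to compound 3 (0.05 log units; within the scatter). For compound 3, the expected value is 12000 nM, with an estimated range from 4500 nM to 32000 nM.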

Compound 3, half-maximal inhibitory concentration: 15700 nM
Compound 3: middle estimate off by 1.3-fold (0.12 log units), on the low side, within the range that was stated.
By their numbers in this assay, from the lowest: compounds 2, 3 and 1 (each within the scatter of the next).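

On the saturated chain carbon bound to two aromatic carbons, (4-methylbenzyl)oxy can replace 2-hydroxyphenyl without a change beyond the scatter in this assay: a 1.2-fold higher number from compound 2 to compound 3 (0.06 log units; within the scatter). The group that enters has no hydrogen-bond donor and more heavy atoms than the group that leaves, yet the number stays within the scatter. No measurement here gives a reason for this result.

Both groups carry a six-membered aromatic ring of carbon only, so the compounds shown do not tell whether this place needs such a ring. As far as these compounds go, what an amine or a carboxylic acid on the same carbon would do remains open.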